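The source may report more compounds than this note shows. Statements on the series, on what has been measured and on what is new or still open speak of the compounds shown alone.

Compound 1 `CCC(C)(C)/N=C(\NC#N)Nc1ccc(I)cc1`: 74 nM
Compound 2 `CC(/N=C(\NC#N)Nc1cccc(C#N)c1)C(C)(C)C`: 350 nM

Of the compounds shown here, two have been measured in an assay on membranes from heart (Canis lupus familiaris) for displacement of a labelled ligand from sulfonylurea receptor 2, Kir6.2 (Homo sapiens); on this read-out lower numbers stand for stronger inhibition and higher numbers for weaker inhibition. Compound 1 gives 74 nM, the lowest of the two numbers, while compound 2 gives 350 nM, a gap that goes beyond the usual scatter of repeated measurements and so marks compound 2 as the weaker inhibitor of the pair. Compound 1 and compound 2 differ from each other in more than one place, so their gap cannot be tied to any single change.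

Compound 3 `CCC(C)(C)/N=C(\NC#N)Nc1ccc(C#N)cc1` has not been measured yet. It differs from compound 1 in one place: cyano in place of iodo on an aromatic carbon. Among the measured compounds shown here, no measured pair shows this single change, so no directly comparable step is available. For the measured compounds named here, compound 2, the only measured compound carrying a cyano group, stands at 350 nM, a weaker number than compound 1 in this assay. On that basis compound 3 is expected to inhibit less strongly than compound 1, with a step of a 3.4-fold higher number from compound 1 to compound 3 (0.53 log units; beyond the scatter) that reaches beyond the scatter. The estimate for compound 3 is 250 nM, within a range from 70 nM to 900 nM.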

Compound 3, inhibition constant: 160 nM
Compound 3: the middle estimate sits 1.6-fold (0.19 log units) above what was measured; low and high end bracket the measured number.
By their numbers in this assay, from the lowest: compound 1; then compound 3; then compound 2.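

In this assay, among the compounds shown here, the exchange of iodo for cyano on the aromatic carbon para to a large group gives a 2.2-fold higher number from compound 1 to compound 3 (0.33 log units; beyond the scatter) and is the first step here that can be tied to a single change. The step is modest but beyond the scatter, so what sits at this position does affect the number, and iodo gives the lower value of this pair. Compound 3 carries cyano, with 2 heavy atoms and 1 hydrogen-bond acceptor in place of the 1 heavy atom and no acceptor of iodo, and no measurement at hand accounts for the step. Going by these compounds, whether other groups at this position, such as fluoro, methoxy or an amine, would give numbers nearer to compound 1 or further from it remains open. For the compounds shown here, it is also open whether the same exchange of iodo for cyano would give a step of similar size with another alkyl chain in place of the one that compound 1 and compound 3 share.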